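Exchanging one group on the carbonyl of compound 2

The compounds below may be only part of what the source reports. "The series", "measured", "known", "first", "only" and "open" are said of these compounds alone.

Compound 2 (`C[C@@]1(c2cc(NC(=O)c3coc(C(F)F)n3)ccc2F)C=C(CF)OC(N)=N1`) gives 84% in an ADME assay on microsomes from liver (Homo sapiens) for metabolic stability, read by LC-MS, using NADPH, with a stated time of 30 min, tested at 0.1 uM (on this read-out lower numbers stand for a less stable compound and higher numbers for a more stable compound), and compound 1 (`C[C@@]1(c2cc(NC(=O)c3cnc(OCF)cn3)ccc2F)C=C(CF)OC(N)=N1`) gives 86% there, two values within the scatter of each other. Compound 3 (`COc1cnc(C(=O)Nc2ccc(F)c([C@]3(C)C=C(CF)OC(N)=N3)c2)cn1`) has 5-methoxypyrazin-2-yl in place of 2-(difluoromethyl)-1,3-oxazol-4-yl on a carbonyl carbon. Among the compounds with values here, the only measured step that bears on this is a number 2 percentage points lower from compound 1 to compound 2 (within the scatter) with 2-(difluoromethyl)-1,3-oxazol-4-yl in place of 5-(fluoromethoxy)pyrazin-2-yl on that carbon. Within the data shown here, the group entering compound 3 is not the same as the one in compound 1, so this single step is only a rough guide. Going by it, no change beyond the scatter is expected. The expected size is a number 2 percentage points lower from compound 2 to compound 3 (within the scatter) by this estimate. For compound 3 the estimated value is 82% (70% to 92%).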

Compound 3, percent of the compound remaining: 80%
For compound 3 the middle estimate is 2 percentage points above the measured one, within the range that was stated.
By their numbers in this assay, from the lowest: compounds 3, 2 and 1 (each within the scatter of the next).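

In this assay, putting 5-methoxypyrazin-2-yl in place of 2-(difluoromethyl)-1,3-oxazol-4-yl on this carbonyl carbon gives a number 4 percentage points lower from compound 2 to compound 3 (within the scatter), so this exchange of a five-membered for a six-membered aromatic ring leaves the read-out within the usual spread of repeats. Hydrogen in place of fluoro on the saturated chain carbon bound to the ring oxygen gives a number 6 percentage points lower from compound 1 to compound 3 (within the scatter), so this read-out does not separate the methoxy group from the fluoromethoxy group. Nothing available here gives a reason for these results.

As far as these compounds go, all three compounds carry an aromatic ring on this carbonyl carbon, so it remains open how a saturated ring bearing an amine or an aromatic ring bearing a carboxylic acid would behave there. A longer chain on the oxygen, such as ethoxy, is also an open case.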